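The source may report more compounds than this note shows. Statements on the series, on what has been measured and on what is new or still open speak of the compounds shown alone.

The measured compounds in an assay on HEK293 cells for inhibition of Steryl-sulfatase (Homo sapiens), tested at 0.1 uM; on this read-out higher numbers stand for a stronger effect at the one concentration tested and lower numbers for a weaker effect:
compound 1 `NS(=O)(=O)Oc1ccc2c(c1)CN(C(=O)c1cccc(N3CCC(N4CCCCC4)CC3)c1)CC2` gives 0%;
compound 2 `NS(=O)(=O)Oc1ccc2c(c1)CN(C(=O)c1cccc(N3CCCCC3)c1)CC2` gives 1%;
compound 3 `CN(C)CCN(Cc1ccccc1)c1ccc(C(=O)N2CCc3ccc(OS(N)(=O)=O)cc3C2)cc1` gives 13.9%.

Compound 2 stands second highest of these three numbers: compound 1 lies within the scatter of it, while compound 3 sits beyond the scatter above it. Compound 4 `CN(CCN1CCCCC1)c1cccc(C(=O)N2CCc3ccc(OS(N)(=O)=O)cc3C2)c1` differs from compound 2 by methyl(2-(piperidin-1-yl)ethyl)amino in place of piperidin-1-yl on an aromatic carbon. Within the data shown here, only one measured step touches the amine part of the shared core: a number 1 percentage points higher from compound 1 to compound 2 (within the scatter), where hydrogen in place of piperidin-1-yl on a saturated ring carbon stayed within the scatter. Among the measured compounds shown here, compound 3 gives a higher number, but no single-change step links it to compound 2. A small step is therefore expected in this assay, a number 5 percentage points higher from compound 2 to compound 4 (within the scatter). Compound 4 is estimated at 6%, within 0% to 20%.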

Compound 4, a percentage reported as inhibition, at one concentration (the size of the read-out at that concentration, not a potency): 24.5%
The estimate for compound 4 lay 18.5 percentage points below the measured number; the whole stated range lies below it.
By their numbers in this assay, from the lowest: compounds 1 and 2 (each within the scatter of the next); then compound 3; then compound 4.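

In this assay, among these compounds, replacing piperidin-1-yl on this aromatic carbon with methyl(2-(piperidin-1-yl)ethyl)amino gives a number 23.5 percentage points higher from compound 2 to compound 4 (beyond the scatter) and is the only single-change step here beyond the scatter. This position therefore responds to the group placed on it, unlike the saturated ring carbon changed in the earlier step. No measurement here accounts for the rise.

This change adds a chain and a second nitrogen at once, and the compounds shown do not separate the two. Going by these compounds, whether a plain dimethylamino group or a longer chain ending in morpholine would do the same remains open.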